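The source may hold more compounds than are shown below. What is called first, only, known or untested is meant among the compounds shown, and "the series" means these compounds.

Working notes on the series. Among the measured compounds shown here, of the two numbers measured in a functional assay on HeLa cells (Homo sapiens) for inhibition (on this read-out higher numbers stand for weaker inhibition and lower numbers for stronger inhibition), compound 2 `O=C1O/C(=C\Cn2cc(Cl)c(=O)[nH]c2=O)C(OCc2ccccc2)=C1OCc1ccccc1` gives 30000 nM and its only neighbour, compound 1 `O=C1O/C(=C\Cn2cc(C(F)(F)F)c(=O)[nH]c2=O)C(OCc2ccccc2)=C1OCc1ccccc1`, gives 60000 nM in this assay; the single measured step, a 2.0-fold lower number from compound 1 to compound 2 (0.30 log units; within the scatter), is within the scatter, so the two stand level rather than ordered. Compound 3 `O=C1O/C(=C\Cn2cc(F)c(=O)[nH]c2=O)C(OCc2ccccc2)=C1OCc1ccccc1` has not yet been measured in this assay. It differs from compound 2 by fluoro in place of chloro on an aromatic carbon. For the measured compounds named here, the one step that bears on this is the earlier swap at the same position, trifluoromethyl to chloro, which gave a 2.0-fold lower number from compound 1 to compound 2 (0.30 log units; within the scatter) and did not leave the scatter. Exchanging chloro for fluoro is a change of the same kind, and no step beyond the scatter is expected in this assay in either direction. Compound 3 is therefore estimated in this assay at 40000 nM, with a range of 15000 nM to 100000 nM. The expected step is a 1.3-fold higher number from compound 2 to compound 3 (0.12 log units; within the scatter).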

Compound 3, half-maximal inhibitory concentration: 40000 nM
For compound 3 middle estimate and measured number coincide at the digits printed, within the range that was stated.
By their numbers in this assay, from the lowest: compounds 2, 3 and 1 (each within the scatter of the next).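

In this assay the new fluoro member stands level with both earlier compounds, with a 1.3-fold higher number from compound 2 to compound 3 (0.12 log units; within the scatter) on one side and a 1.5-fold lower number from compound 1 to compound 3 (0.18 log units; within the scatter) on the other. Among the compounds shown here, with three groups now read at this aromatic carbon, fluoro, chloro and trifluoromethyl stand level in every pairing, where the earlier compounds gave only a single pair. No supporting measurement is available to explain this flat response.

Still open, from the compounds shown here alone, is whether a group of another kind at this position, such as an amine, a carboxylic acid or a longer chain, would give a step beyond the scatter. Also open, going by these compounds, is whether plain hydrogen at this carbon would stand level with these three groups.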